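This account rests on a few compounds, and the source may have more. Where it says the series, first, only, none or still open, it means among the compounds named here.

In a functional assay on HOP-62 cells (Homo sapiens) for inhibition, read by sulforhodamine B assay (on this read-out lower numbers stand for stronger inhibition of growth and higher numbers for weaker inhibition of growth), compound 1 (`c1ccc(-c2ccc(-c3ccc(-c4nc5ccccc5[nH]4)cc3)cc2)cc1`) gives 100000 nM as the highest of three measured numbers. Compound 2 (`Cc1ccc2[nH]c(-c3ccc(-c4ccc(-c5ccc(N(C)C)cc5)cc4)cc3)nc2c1`) gives 4230 nM and compound 3 (`Cc1ccc2[nH]c(-c3ccc(-c4ccc(-c5cccc(Cl)c5)cc4)cc3)nc2c1`) gives 2740 nM but each differs from compound 1 in more than one place. Compound 4 (`COc1ccc(-c2ccc(-c3ccc(-c4nc5ccccc5[nH]4)cc3)cc2)cc1`) carries a single change from compound 1, methoxy in place of hydrogen on an aromatic carbon. Going by the values given here, the only measured single-place step (a 1.5-fold lower number from compound 2 to compound 3 (0.19 log units; within the scatter)) swaps one substituted phenyl for another and bears only loosely on this change. With compounds 2 and 3 both far lower than compound 1, a lower number beyond the scatter is expected, though the data do not show how much of those gaps belongs to such a group. The expected step (an 8.3-fold lower number from compound 1 to compound 4 (0.92 log units; beyond the scatter)) is therefore a drop. Compound 4 is estimated at 12000 nM with 3000 nM to 60000 nM as the expected range.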

Compound 4, concentration for 50% growth inhibition: 100000 nM
The estimate for compound 4 lay 8.3-fold (0.92 log units) below the measured number, outside the stated range (above it).
By their numbers in this assay, from the lowest: compounds 3 and 2 (each within the scatter of the next); then compounds 1 and 4 (each within the scatter of the next).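

In this assay, the swap of phenyl for 4-methoxyphenyl gives no change at the digits printed from compound 1 to compound 4 (within the scatter). Methoxy at this place, para to a large group, is therefore not enough on its own to strengthen growth inhibition on the core of compound 1. Nothing available explains this result.

The compounds shown leave open whether a different group at this place, such as a hydroxyl group or a carboxylic acid, would shift the number. They also cannot show which of their several differences from compound 1 accounts for the lower numbers of compound 2 and compound 3.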